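The source may report more compounds than this note shows. Statements on the series, on what has been measured and on what is new or still open speak of the compounds shown alone.

Compound 1 `COc1cccc(/C=N/NC(=O)c2cccnc2Nc2cccc(C(F)(F)F)c2)c1`: 49.7%
Compound 2 `CNc1ncccc1C(=O)N/N=C/c1cccc(Cl)c1`: 61.7%

Of the compounds shown here, two have been measured in a functional assay on the whole organism (strain Wistar) for inhibition, with Rattus norvegicus as the target, read by paw edema, with a stated time of 2 h, at a dose of 10 mg/kg by the intraperitoneal route; a lower number here means less inhibition, a higher number more inhibition at the dose given (going by the name of the read-out). Compound 2 stands highest of the two numbers; compound 1 is the nearest, and its value is lower by a gap beyond the usual scatter. Going by the values given here, no pair among the measured compounds differs in only one place, so no single change has yet been tied to a shift in the read-out.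

Compound 3 `CNc1ncccc1C(=O)N/N=C/c1cccc(OC)c1` is the next compound, and it differs from compound 2 in one place: methoxy in place of chloro on an aromatic carbon. Compound 1 also carries a methoxy, but it differs from compound 2 in further places as well, so its lower value cannot be laid on the methoxy alone.

Among the compounds with values here, with no measured step of this kind to lean on, the expected step from compound 2 to compound 3 is small, a number 6.7 percentage points lower from compound 2 to compound 3 (within the scatter), not beyond the scatter and of uncertain direction. Compound 3 is estimated at 55%, with a range from 40% to 70%.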

Compound 3, a percentage reported as inhibition, in the whole organism at one dose (the size of the read-out at that dose, not a potency): 51.5%
For compound 3 the middle estimate is 3.5 percentage points above the measured one; the measured number falls inside the stated range.
By their numbers in this assay, from the lowest: compounds 1 and 3 (each within the scatter of the next); then compound 2.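

In this assay, going by these compounds alone, replacing chloro with methoxy on the aromatic carbon meta to a large group gives a number 10.2 percentage points lower from compound 2 to compound 3 (beyond the scatter) and ties a single change to a modest shift for the first time, showing that the group at this place can matter. By contrast, methyl in place of 3-(trifluoromethyl)phenyl on a nitrogen on an aromatic ring gives a number 1.8 percentage points higher from compound 1 to compound 3 (within the scatter), so even this large exchange produces no shift that stands out from the scatter in these methoxy compounds. No measurement here explains either result.

Going by these compounds, whether chloro would still lead if an amine, a nitrile or a carboxylic acid stood at the same aromatic carbon remains open. Within the data shown here, also open is whether the single step from chloro to methoxy would hold at other doses or times.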